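The source may hold more compounds than are shown below. What is called first, only, known or untested is meant among the compounds shown, and "the series" means these compounds.

Compounds measured so far:
compound 1, `O=S(=O)(Nc1nnc(SCc2ccc(Cl)cc2)s1)c1ccccc1`: 89%
compound 2, `Cc1cc(C)c(S(=O)(=O)Nc2nnc(SCc3ccccc3)s2)c(C)c1`: 73%

Both were run in a toxicity assay on HaCaT cells (Homo sapiens) for cytotoxicity, tested at 125 uM; a higher number here means a weaker effect of the compound at the concentration tested, a lower number a stronger effect. Compound 2 holds the lower of the two numbers in this assay; compound 1 sits higher by a margin beyond the usual scatter. The two compounds differ in more than one place, so no single structural change can be read out of that gap.

Compound 3, `Cc1cc(C)c(S(=O)(=O)Nc2nnc(SCc3ccc(Cl)cc3)s2)c(C)c1`, has not yet been measured in this assay. Relative to compound 2 the change is chloro in place of hydrogen on an aromatic carbon. Within the data shown here, no measured pair isolates this change, so its effect in this assay is not known from the data at hand. The step of a number 3 percentage points lower from compound 2 to compound 3 (within the scatter) is expected to be small, most likely within the scatter, with at most a slight lean toward a lower number. Compound 3 is therefore estimated at 70% in this assay, with a range from 50% to 90%.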

Compound 3, a percentage reported as activity, at one concentration (the size of the read-out at that concentration, not a potency): 87%
Estimate against measurement, compound 3: 17 percentage points below, and the stated range covers the measured number.
By their numbers in this assay, from the lowest: compound 2; then compounds 3 and 1 (each within the scatter of the next).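

Working notes: in this assay the change from benzylsulfanyl to (4-chlorobenzyl)sulfanyl can now be read on its own, with the 2,4,6-trimethylphenyl group held fixed. Chloro in place of hydrogen, para to a large group, gives a number 14 percentage points higher from compound 2 to compound 3 (beyond the scatter) and so a weaker effect at the concentration tested. With the 4-chlorobenzyl group held fixed, the sulfonyl side gives a number 2 percentage points lower from compound 1 to compound 3 (within the scatter) and so does not separate phenyl from 2,4,6-trimethylphenyl, while no measurement at hand bears on the reason for either step.

As far as these compounds go, whether the chloro step carries over when phenyl sits on the sulfonyl sulfur remains open. So does whether fluoro, methoxy or an amine at this same aromatic carbon would read like chloro or like hydrogen.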